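The source may hold more compounds than are shown below. What is called first, only, known or untested is meant among the compounds shown, and "the series" means these compounds.

Measured in a functional assay on MDA-MB-231 cells (Homo sapiens) for inhibition, read by sulforhodamine B assay (a higher number here means a weaker inhibitor, a lower number a stronger inhibitor), each value being a limit of the assay and not a number:

Compound 1 `COC(=O)CC/C(C)=C/Cc1c(OC)c(C)c2c(c1OCC#CCN1CCN(c3ccc(O)cc3)CC1)C(=O)OC2`: > 50000 nM
Compound 2 `COC(=O)CC/C(C)=C/Cc1c(OC)c(C)c2c(c1OCC#CCN1CCN(Cc3ccc(Cl)cc3)CC1)C(=O)OC2`: > 50000 nM
Compound 3 `COC(=O)CC/C(C)=C/Cc1c(OC)c(C)c2c(c1OCC#CCN1CCN(C(c3ccccc3)c3ccc(Cl)cc3)CC1)C(=O)OC2`: > 50000 nM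

Compound 2 has no number, only the limit > 50000 nM. It is not alone there, as the series shows (the limit of > 50000 nM in this assay, at which 3 of the 3 values shown sit).

Compound 4 `COC(=O)CC/C(C)=C/Cc1c(OC)c(C)c2c(c1OCC#CCN1CCN(c3ccc(C)cc3)CC1)C(=O)OC2` has not yet been measured. Its structure departs from that of compound 2 by 4-methylphenyl in place of 4-chlorobenzyl on an amine nitrogen in a ring. In words, this is 4-methylphenyl in place of 4-chlorobenzyl on an amine nitrogen in a ring.

Two measured changes bear on this one. Replacing 4-hydroxyphenyl with 4-chlorobenzyl on the same amine nitrogen is a step that the two limits leave unreadable from compound 1 to compound 2. Placing phenyl in place of hydrogen on the saturated chain carbon is a step that the two limits leave unreadable from compound 2 to compound 3. Going by the values given here, neither therefore offers a size to carry over, and no compound yet gives a number in this assay. No step beyond the scatter is expected here, and the assay will most likely again report only a limit. The expected change is a number no higher from compound 2 to compound 4 (the limit leaves the size open). For compound 4 the estimated value is 50000 nM, with an expected range from 20000 nM to 100000 nM.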

Compound 4, half-maximal inhibitory concentration: > 50000 nM
Compound 4 was reported as a limit; the forecaster's own chance of this, stated with the estimate: 75%; the middle value lies on the limit itself.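

In this assay compound 4 gives > 50000 nM, which is a limit of the assay and not a number. Compound 1 and compound 2 also have only limits, so neither step to compound 4 can be read. The compounds shown leave open whether any group on this amine nitrogen changes the value, as the whole series rests on one limit: the limit of > 50000 nM in this assay, at which 4 of the 4 values shown sit.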